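A few compounds are considered here, and "the series" means these few. Any claim that something is new, unique, unknown or untested is made for them only; others in the source may bear on it.

Measured in an ADME assay on cells (Homo sapiens) for activation; a higher number here means that more compound is tolerated, a lower number that less compound is tolerated:
compound 1 `COc1ccc2c(OCC[C@@H]3NC(=O)N(C)CCCC/C=C\[C@@H]4C[C@@]4(C(=O)NS(=O)(=O)N(C)C)NC3=O)cc(-c3nc(C(C)C)cs3)nc2c1Cl` — 47800 nM
compound 2 `COc1ccc2c(OCC[C@@H]3NC(=O)N(C)CCCC/C=C\[C@@H]4C[C@@]4(C(=O)NS(=O)(=O)C4(C)CC4)NC3=O)cc(-c3nc(C(C)C)cs3)nc2c1Cl` — 37400 nM
compound 3 `C#CC1(S(=O)(=O)NC(=O)[C@@]23C[C@H]2/C=C\CCCCN(C)C(=O)N[C@@H](CCOc2cc(-c4nc(C(C)C)cs4)nc4c(Cl)c(OC)ccc24)C(=O)N3)CC1` — 26300 nM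

The three numbers cluster: the steps of a 1.8-fold lower number from compound 1 to compound 3 (0.26 log units; within the scatter) and a 1.4-fold lower number from compound 2 to compound 3 (0.15 log units; within the scatter) both lie within the scatter, as does a 1.3-fold lower number from compound 1 to compound 2 (0.11 log units; within the scatter), so compound 3 cannot be separated from the other two. Compound 4 `COc1ccc2c(OCC[C@@H]3NC(=O)N(C)CCCC/C=C\[C@@H]4C[C@@]4(C(=O)NS(=O)(=O)N4CCC[C@H]4C#N)NC3=O)cc(-c3nc(C(C)C)cs3)nc2c1Cl` differs from compound 3 by 2-cyanopyrrolidin-1-yl in place of 1-ethynylcyclopropyl on a sulfonyl sulfur. Among the measured compounds shown here, the steps that bear on it are the two earlier exchanges on the same sulfonyl sulfur, from compound 1 to compound 3 and from compound 2 to compound 3, neither of which moved this assay beyond the scatter. No step beyond the scatter is therefore expected for compound 4. Compound 4 is estimated at 32000 nM, with a range of 13000 nM to 80000 nM. This estimate corresponds to an expected step of a 1.2-fold higher number from compound 3 to compound 4 (0.09 log units; within the scatter).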

Compound 4, half-maximal cytotoxic concentration: 28300 nM
Compound 4: the middle estimate sits 1.1-fold (0.05 log units) above what was measured; the measured number falls inside the stated range.
By their numbers in this assay, from the lowest: compounds 3, 4, 2 and 1 (each within the scatter of the next).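

In this assay, 2-cyanopyrrolidin-1-yl on the sulfonyl sulfur stays within the scatter of all three earlier groups, with a 1.1-fold higher number from compound 3 to compound 4 (0.03 log units; within the scatter) and a 1.3-fold lower number from compound 2 to compound 4 (0.12 log units; within the scatter) and a 1.7-fold lower number from compound 1 to compound 4 (0.23 log units; within the scatter). The series at this position now includes a five-membered ring with a hetero atom, a nitrile and a defined stereocentre, and this assay still separates none of the four compounds. No measurement available explains this flat result.

Going by these compounds, whether a carboxylic acid or a primary amine on the sulfonyl sulfur would also stay within the scatter remains open. So does whether the result holds for changes elsewhere on the shared core.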